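Adding a Second Trifluoromethyl on the Other Core

The source may hold more compounds than are shown below. What is called first, only, known or untested is meant among the compounds shown, and "the series" means these compounds.

The study brings together two pairs of compounds built on different cores. Compound 1 `Cc1nc(N(C)C(=O)NC(=O)c2c(F)cccc2F)sc1C(=O)N/N=C/c1cccc(C(F)(F)F)c1` and compound 3 `Cc1nc(N(C)C(=O)NC(=O)c2c(F)cccc2F)sc1C(=O)N/N=C/c1cc(C(F)(F)F)cc(C(F)(F)F)c1` share one core; compound 2 `CNc1nc(C(F)(F)F)c(C(=O)N/N=C/c2cccc(C(F)(F)F)c2)s1` and compound 4 `CNc1nc(C(F)(F)F)c(C(=O)N/N=C/c2cc(C(F)(F)F)cc(C(F)(F)F)c2)s1` share another. The difference between the two cores is not broken down here.

In a functional assay on A549 cells (Homo sapiens) for inhibition, read by MTT assay, with a stated time of 72 h (on this read-out lower numbers stand for stronger inhibition and higher numbers for weaker inhibition), compound 1 gives 30.3 ug/mL. In this assay compound 3 gives 13 ug/mL. The change that separates them is trifluoromethyl in place of hydrogen on an aromatic carbon, and it brought a 2.3-fold lower number from compound 1 to compound 3 (0.37 log units; beyond the scatter).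

Compound 2 stands apart: in this assay compound 2 gives > 100 ug/mL, which is a limit of the assay and not a number (the limit of > 100 ug/mL in this assay, at which 1 of the 3 values shown sits).

Compound 4 is not yet measured. It differs from compound 2 by trifluoromethyl in place of hydrogen on an aromatic carbon, the same change, in the same surroundings, as that made from compound 1 to compound 3, so this change occurs twice among the compounds shown.

On the second core the step is expected to be an at least 1.2-fold lower number from compound 2 to compound 4 (0.09 log units; that floor lies within the scatter), resting on the modest step of a 2.3-fold lower number from compound 1 to compound 3 (0.37 log units; beyond the scatter) seen on the first core. As compound 2 gives only a limit, the starting point for this step is not fixed, and a limit for compound 4 remains a real possibility. Compound 4 is therefore expected to give about 80 ug/mL in this assay, within a broad range from 30 ug/mL to 250 ug/mL.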

Compound 4, half-maximal inhibitory concentration: > 100 ug/mL
Compound 4 gave a limit, no number; the forecaster's own chance of this, stated with the estimate: 50%; at least 1.2-fold (0.09 log units) between middle value and limit.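

Among the compounds shown here, compound 4, like compound 2, gives only a limit of the assay and not a number in this assay, so no step between the two can be read: the limit of > 100 ug/mL in this assay, at which 2 of the 4 values shown sit. The compounds shown leave open whether the added trifluoromethyl changes inhibition at all on the core shared by compound 2 and compound 4, as it does on the core of compound 1 and compound 3.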